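The compounds below may be only part of what the source reports. "The series", "measured", "known", "first", "only" and "open" are said of these compounds alone.

In a functional assay on NCI-H23 cells (Homo sapiens) for antiproliferative activity, read by sulforhodamine B assay (a higher number here means a weaker inhibitor of growth, a lower number a stronger inhibitor of growth), compound 1 `CC(C)CCCOc1cccc(O)c1C(=O)/C=C/c1ccc(O)cc1` gives 11400 nM and compound 2 `CC(C)(C)CCOc1cccc(O)c1C(=O)/C=C/c1ccc(O)cc1` gives 3130 nM. The step between them is clear: a 3.6-fold lower number from compound 1 to compound 2 (0.56 log units; beyond the scatter). For compound 3 `O=C(/C=C/c1ccc(O)cc1)c1c(O)cccc1OCC1CCCCC1`, this assay gives only a limit, > 30000 nM. As far as these compounds go, compound 3 therefore stands as the weakest of the three, and its exact value is unknown. Two measured steps lead to it: an at least 2.6-fold higher number from compound 1 to compound 3 (0.42 log units; beyond the scatter) and an at least 9.5-fold higher number from compound 2 to compound 3 (0.98 log units; beyond the scatter). Both are lower bounds on the true size of the change.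

Compound 4 `CCCCOc1cccc(O)c1C(=O)/C=C/c1ccc(O)cc1` has not yet been measured. It carries propyl in place of cyclohexyl on a saturated chain carbon bound to an oxygen on an aromatic ring. The ring is gone, so the side chain is open, as it is in compound 1 and compound 2. These two steps, read in reverse, suggest that the number should fall, and the size of the drop is likely to be modest or larger. Compound 4 is expected to land nearest compound 1, at 11400 nM, with compound 2, at 3130 nM, marking the stronger side. The expected change is an at least 3.3-fold lower number from compound 3 to compound 4 (0.52 log units; beyond the scatter). For compound 4, the estimate is 9000 nM, with an expected range of 3000 nM to 27000 nM.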

Compound 4, concentration for 50% growth inhibition: > 30000 nM
Compound 4: a limit, no number (the forecaster's own chance of this, stated with the estimate: 10%); middle value at least 3.3-fold (0.52 log units) from the limit.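

Compound 4 gives > 30000 nM in this assay, and this is a limit of the assay, not a number. Removing the ring from this side chain is therefore not enough on its own to give a measurable result: the unbranched butoxy chain shows an at least 9.5-fold higher number from compound 2 to compound 4 (0.98 log units; beyond the scatter) and an at least 2.6-fold higher number from compound 1 to compound 4 (0.42 log units; beyond the scatter), so among the open chains shown, only the branched ones in compound 1 and compound 2 give a number, while cyclohexylmethoxy in compound 3 also stays at the limit. The step from compound 3 to compound 4 cannot be read, and no order between these two compounds can be given: the limit of > 30000 nM in this assay, at which 2 of the 4 values shown sit.

The compounds shown leave open whether branching or chain length matters more, since the chain of compound 4 differs from those of compound 1 and compound 2 in both respects. A straight hexyl chain would help to separate these two features, and an amine at the end of the chain would test whether this position accepts anything other than carbon.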